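This account rests on a few compounds, and the source may have more. Where it says the series, first, only, none or still open, it means among the compounds named here.

Measured compounds:
compound 1 `COc1cc(-c2cc(C(=O)O)c3ccccc3n2)ccc1OCC(=O)Nc1cccc(F)c1`, 1.6
compound 2 `COc1cc(-c2cc(C(=O)O)c3ccccc3n2)ccc1OCC(=O)Nc1ccc(C(F)(F)F)cc1`, 1.6

In a physicochemical assay for lipophilicity, using the shake flask method, in phosphate buffer, measured as octanol-water partition, at pH 7.4 (on this read-out lower numbers stand for lower lipophilicity and higher numbers for higher lipophilicity), compound 2 gives 1.6. Compound 1 gives 1.6, and the step of no change at the digits printed from compound 1 to compound 2 (within the scatter) leaves compound 2 level with compound 1 at the digits shown, within the scatter.

Compound 3 `COc1cc(-c2cc(C(=O)O)c3ccccc3n2)ccc1OCC(=O)NC1CCCCC1` is not yet measured. It differs from compound 2 in one place: cyclohexyl in place of 4-(trifluoromethyl)phenyl on an amide-type nitrogen. Among the compounds with values here, the only measured step in this assay, no change at the digits printed from compound 1 to compound 2 (within the scatter), exchanges one six-membered aromatic ring for another on the same amide-type nitrogen, whereas the step to compound 3 brings in a six-membered non-aromatic ring of carbon only in place of an aromatic one, so the measured step does not cover this kind of exchange directly. It does show that a change of the group on this nitrogen left the read-out unmoved once. On that basis a small step is expected for compound 3, a number 0.10 log units higher from compound 2 to compound 3 (within the scatter), not clearly beyond the scatter in either direction. Compound 3 is estimated at 1.7, with a range from 1.2 to 2.2.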

Compound 3, distribution coefficient: 0.8
Beside the measured number, compound 3's estimate is 0.90 log units above it; the measured number lies below the stated range.
By their numbers in this assay, from the lowest: compound 3; then compounds 1 and 2 (each within the scatter of the next).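

In this assay the group on the amide-type nitrogen can clearly move the read-out: cyclohexyl gives a number 0.80 log units lower from compound 2 to compound 3 (beyond the scatter) and, against the other aromatic partner, a number 0.80 log units lower from compound 1 to compound 3 (beyond the scatter). Among these three compounds, the exchange between 3-fluorophenyl and 4-(trifluoromethyl)phenyl gave no change at the digits printed from compound 1 to compound 2 (within the scatter), whereas the only exchange of an aromatic ring for a six-membered non-aromatic ring of carbon only shifted the number by the same amount from either aromatic partner, so the earlier flat step does not extend to this kind of change. No measurement at hand accounts for the shift.

With cyclohexyl as the only non-aromatic group at this place, the compounds shown cannot separate the change from aromatic to non-aromatic ring from the loss of the fluorine-bearing substituents, and an unsubstituted phenyl on the same nitrogen would bear directly on that question. Going by these compounds, whether the lower number holds for other non-aromatic groups, such as cyclopentyl, cyclohexylmethyl or a piperidine ring carrying a basic amine, also remains open.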